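Trimming an isopropyl to ethyl on a glycosyl cinnamamide

A few compounds are considered here, and "the series" means these few. Any claim that something is new, unique, unknown or untested is made for them only; others in the source may bear on it.

Two glycosylamides from this series have been measured in an ADME assay on Caco-2 cells (Homo sapiens) for permeability; on this read-out higher numbers stand for higher permeability and lower numbers for lower permeability. Compound 1, `CC(C)c1ccc(/C=C/C(=O)N[C@@H]2O[C@H](CO)[C@@H](O)[C@H](O)[C@H]2O)cc1`, gives 98.5 nm/s in this assay, which is the lower of the two numbers recorded so far. Compound 2, `CC(C)c1ccc(C[C@H](C)C(=O)N[C@@H]2O[C@H](CO)[C@@H](O)[C@H](O)[C@H]2O)cc1`, gives 98.7 nm/s in this assay, and since the two values lie within the usual scatter of repeated measurements, nothing separates compound 1 from compound 2 on this read-out.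

Compound 3, `CCc1ccc(/C=C/C(=O)N[C@@H]2O[C@H](CO)[C@@H](O)[C@H](O)[C@H]2O)cc1`, has not yet been measured in this assay. It differs from compound 1 in one place only: hydrogen in place of methyl on a saturated chain carbon bound to an aromatic carbon and a saturated chain carbon. The rest of the shared core, the unsaturated amide and the sugar, is kept as it stands in compound 1.

Without any pair of measured compounds that differ in this same way, the size of the step cannot be read from the data. The loss of a single carbon is expected to matter little, so the step of a 1.2-fold lower number from compound 1 to compound 3 (0.09 log units; within the scatter) is estimated to be small, if anything a slight decrease, and probably within the scatter. Compound 3 is therefore expected to give about 80 nm/s in this assay, with a plausible range from 45 nm/s to 150 nm/s.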

Compound 3, apparent permeability: 94.7 nm/s
Compound 3: middle estimate off by 1.2-fold (0.07 log units), on the low side; the range from low to high includes it.
By their numbers in this assay, from the lowest: compounds 3, 1 and 2 (each within the scatter of the next).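

For the compounds shown here, the trim from isopropyl to ethyl gives the first step that can be read at this position: in this assay, hydrogen in place of methyl on a saturated chain carbon bound to an aromatic carbon and a saturated chain carbon comes to (a 1.0-fold lower number from compound 1 to compound 3 (0.02 log units; within the scatter)). Until now, neither compound had shown what this chain contributes, since both carry the isopropyl; the step shows that, on the core of compound 1, removing one carbon from it leaves the read-out within the scatter. No measured evidence bears on why this change has so small an effect.

The compounds shown leave open whether the read-out stays within the scatter when the group at this place goes further, to a plain methyl, or the other way, to a longer chain such as n-butyl, and whether an amine or a carboxylic acid there would move it beyond the scatter. They also leave open whether the same trim from isopropyl to ethyl would give a similar step on the saturated amide of compound 2.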